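Cytotoxicity notes: thiophen-2-yl in place of phenyl

The compounds below may be only part of what the source reports. "The series", "measured", "known", "first", "only" and "open" are said of these compounds alone.

Compound 1 `Oc1cccc(-c2cc(-c3ccccc3)cc(-c3cccs3)n2)c1` gives 17000 nM in this series
Compound 2 `Oc1ccc(-c2cc(-c3ccccc3)cc(-c3ccccc3)n2)cc1` gives 1700 nM in this series

Both numbers come from a functional assay on HeLa cells (Homo sapiens) for cytotoxicity, read by ELISA, with a stated time of 2 days (on this read-out lower numbers stand for stronger inhibition and higher numbers for weaker inhibition), and are the only two measured so far. Compound 2 has the lower number, and its gap to compound 1 lies beyond the scatter.

The next compound is compound 3 `Oc1ccc(-c2cc(-c3ccccc3)cc(-c3cccs3)n2)cc1`, which keeps the 4-hydroxyphenyl group of compound 2 and changes one group: thiophen-2-yl in place of phenyl on an aromatic carbon on an aromatic carbon next to the ring nitrogen. For the measured compounds named here, no measured pair isolates this change. Compound 1 with 17000 nM also carries thiophen-2-yl and sits higher, but compound 1 and compound 2 differ in more than one place, so that gap cannot be assigned to thiophen-2-yl alone.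

A modest rise in this assay is therefore expected, possibly no larger than the scatter, and well short of the whole gap between the two measured compounds. The expected change is a 1.8-fold higher number from compound 2 to compound 3 (0.25 log units; within the scatter) in this direction. For compound 3 the estimated value is 3000 nM with a range from 1000 nM to 11000 nM in this read-out.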

Compound 3, half-maximal inhibitory concentration: 1700 nM
Beside the measured number, compound 3's estimate is 1.8-fold (0.25 log units) above it; measured number inside the range.
By their numbers in this assay, from the lowest: compounds 2 and 3 (each within the scatter of the next); then compound 1.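

In this assay, the exchange of phenyl for thiophen-2-yl on the aromatic carbon next to the ring nitrogen now has a clean pair, and it gives no change at the digits printed from compound 2 to compound 3 (within the scatter), so this read-out does not separate the two rings at this position when 4-hydroxyphenyl is present. With thiophen-2-yl held constant, 4-hydroxyphenyl in place of 3-hydroxyphenyl gives a 10-fold lower number from compound 1 to compound 3 (1.00 log units; beyond the scatter), which is the first single-place step in the series to lie beyond the scatter and places the larger difference among these compounds on the hydroxyphenyl group. No measurement at hand gives a cause for either step.

Whether the thiophen-2-yl result would also hold with 3-hydroxyphenyl in the molecule remains open, as the shown compounds test the phenyl exchange only beside 4-hydroxyphenyl. As far as these compounds go, it is also open how this position would respond to groups unlike either ring, such as an amine, a carboxylic acid or a longer alkyl chain, and how a methoxy group would compare with the hydroxyl on the hydroxyphenyl ring.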